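Swapping benzyloxy for cyclopentylsulfanyl on a tolerant core

The compounds below may be only part of what the source reports. "The series", "measured", "known", "first", "only" and "open" are said of these compounds alone.

Three compounds share one core and differ only in the group on an aromatic carbon. Compound 1 `CCCCSc1nc(N)nc2c1ncn2/C=C1/CC1(CO)CO` carries butylsulfanyl, compound 2 `Nc1nc(OCC(F)(F)F)c2ncn(/C=C3/CC3(CO)CO)c2n1` carries 2,2,2-trifluoroethoxy and compound 3 `Nc1nc(OCc2ccccc2)c2ncn(/C=C3/CC3(CO)CO)c2n1` carries benzyloxy. In an ADME assay on MOLT-3 cells (Homo sapiens) for cytotoxicity, with a stated time of 7 days (a lower number here means that less compound is tolerated, a higher number that more compound is tolerated), compound 1 gives > 20000 nM, a limit of the assay rather than a number. In this assay compound 2 also gives only a limit, > 20000 nM. Compound 3 likewise reaches only a limit, > 20000 nM. Because (the limit of > 20000 nM in this assay, at which 3 of the 3 values shown sit), none of the steps among them can be sized: a step that the two limits leave unreadable from compound 1 to compound 3, a step that the two limits leave unreadable from compound 2 to compound 3 and a step that the two limits leave unreadable from compound 1 to compound 2. Compound 4 `Nc1nc(SC2CCCC2)c2ncn(/C=C3/CC3(CO)CO)c2n1` differs from compound 3 in one place: cyclopentylsulfanyl in place of benzyloxy on an aromatic carbon. The closest guide is a step that the two limits leave unreadable from compound 1 to compound 3. That step also exchanges butylsulfanyl and benzyloxy on that aromatic carbon, yet its size stays hidden by the two limits. The step that the limit leaves unreadable from compound 3 to compound 4 is therefore expected to be none beyond the scatter. Compound 4 is expected to give 40000 nM, within 15000 nM to 150000 nM, most likely once more as a limit.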

Compound 4, half-maximal cytotoxic concentration: > 20000 nM
Compound 4 was reported as a limit; the forecaster's own chance of this, stated with the estimate: 85%; the middle value lies beyond the limit too.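

No step from compound 1, compound 2 or compound 3 to compound 4 can be read, because all four compounds give only a limit and no number: the limit of > 20000 nM in this assay, at which 4 of the 4 values shown sit.

The compounds shown leave open whether the group on that aromatic carbon changes the tolerated concentration in this assay at all.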